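Halogen swap on a benzylthio arm in a rat artery model

The source may hold more compounds than are shown below. What is called first, only, known or untested is meant among the compounds shown, and "the series" means these compounds.

The series comprises compound 1 `CC1=C(C(=O)Nc2ccc(F)cc2)C(c2ccc([N+](=O)[O-])cc2)N=C(SCc2ccc(Cl)cc2)N1`, compound 2 `CC1=C(C(=O)Nc2ccc(F)cc2)C(c2ccc([N+](=O)[O-])cc2)N=C(SCc2ccc(F)cc2)N1`, compound 3 `CC1=C(C(=O)Nc2ccc(Br)cc2)C(c2ccc(Cl)cc2Cl)N=C(SCc2ccc(Cl)cc2)N1` and the unmeasured compound 4 `CC1=C(C(=O)Nc2ccc(Br)cc2)C(c2ccc(Cl)cc2Cl)N=C(SCc2ccc(F)cc2)N1`. In a functional assay on the whole organism (artery, strain albino) with Rattus norvegicus as the target, with a stated time of 720 min, at a dose of 10 mg/kg by the oral route (on this read-out lower numbers stand for less inhibition and higher numbers for more inhibition at the one dose given (going by the name of the read-out)), compound 1 gives 22.2%, compound 2 gives 19.6% and compound 3 gives 25.8%. Compound 2 differs from compound 1 by fluoro in place of chloro on an aromatic carbon, and this change gave a number 2.6 percentage points lower from compound 1 to compound 2 (within the scatter). How the core of compound 3 differs from that of compound 1 is not broken down here. Compound 4 differs from compound 3 by fluoro in place of chloro on an aromatic carbon, the same change at the same place. This step is expected to be a number 2.8 percentage points lower from compound 3 to compound 4 (within the scatter), which rests on a number 2.6 percentage points lower from compound 1 to compound 2 (within the scatter). Compound 4 is therefore expected to give 23%, with a likely range from 13% to 33%.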

Compound 4, a percentage reported as inhibition, in the whole organism at one dose (the size of the read-out at that dose, not a potency): 27.3%
The estimate for compound 4 lay 4.3 percentage points below the measured number; the range from low to high includes it.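

In this assay, fluoro in place of chloro on the benzyl arm gave a number 1.5 percentage points higher from compound 3 to compound 4 (within the scatter). Set beside the earlier step, the change reads alike on the two cores: the same change on two cores in this assay, a number 2.6 percentage points lower (within the scatter) from compound 1 to compound 2 and a number 1.5 percentage points higher (within the scatter) from compound 3 to compound 4, 4.1 percentage points apart, within the scatter of two such steps This shows that on both cores the swap stayed within the usual scatter and that the two steps cannot be told apart, but it does not show that the change has any real effect that carries from one core to the other.

The compounds shown leave open whether an amine, a carboxylic acid or a methoxy group in place of the halogen on the benzyl arm would shift the read-out beyond the scatter. They also leave open how the same swap reads on a third core.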